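From a Bromophenyl to a Dihydroxyphenyl Arm

This account rests on a few compounds, and the source may have more. Where it says the series, first, only, none or still open, it means among the compounds named here.

Three compounds have been measured:
Compound 1, `COc1ccc(/C=C2\CCC/C(=C\c3cccc(OC)c3OC)C2=O)cc1`, gives 18600 nM in a functional assay on MCF7 cells (Homo sapiens) for cytotoxicity, read by MTT assay, with a stated time of 72 h; a lower number here means a stronger inhibitor, a higher number a weaker inhibitor.
Compound 2, `COc1cccc(/C=C2\CCC/C(=C\c3cccc(O)c3)C2=O)c1OC`, gives 8800 nM in this assay.
Compound 3, `COc1ccc(/C=C2\CCC/C(=C\c3cccc(Br)c3)C2=O)cc1OC`, gives 5300 nM in this assay.

All three share a core with two aryl arms. Compound 3 has the lowest number of the three; its gap to compound 2 lies within the scatter, while its gap to compound 1 lies beyond it, so compound 3 is not separated from compound 2 but is clearly separated from compound 1.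

Compound 4, `COc1ccc(/C=C2\CCC/C(=C\c3ccc(O)c(O)c3)C2=O)cc1OC`, has not yet been measured. It differs from compound 3 in one place: 3,4-dihydroxyphenyl in place of 3-bromophenyl on a double-bonded chain carbon bound to a double-bonded ring carbon.

For the measured compounds named here, only one measured step concerns a change on that same arm: a 2.1-fold lower number from compound 1 to compound 2 (0.33 log units; beyond the scatter), where a hydroxyl-bearing aryl replaced a methoxy-bearing one. Going by the values given here, that swap is not the same as trading a bromine for two hydroxyls, and no step shows the dihydroxyphenyl itself, so the guidance is thin. A modest movement in either direction, or none beyond the scatter, is the reasonable expectation in this assay.

Compound 4 is therefore expected to give about 6000 nM, within a range from 2500 nM to 14000 nM, which amounts to an estimated step of a 1.1-fold higher number from compound 3 to compound 4 (0.05 log units; within the scatter).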

Compound 4, half-maximal inhibitory concentration: 14400 nM
For compound 4 the middle estimate is 2.4-fold (0.38 log units) below the measured one, and the stated range ends below it.
By their numbers in this assay, from the lowest: compounds 3, 2, 4 and 1 (each within the scatter of the next, the first and the last beyond it).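

At the place on a double-bonded chain carbon bound to a double-bonded ring carbon, the arm is not indifferent to what it carries: in this assay the exchange of 3-bromophenyl for 3,4-dihydroxyphenyl gives a 2.7-fold higher number from compound 3 to compound 4 (0.43 log units; beyond the scatter) and so moves the number upward. The earlier step of 3-hydroxyphenyl in place of 4-methoxyphenyl went the other way, giving a 2.1-fold lower number from compound 1 to compound 2 (0.33 log units; beyond the scatter), so hydroxyl groups on an arm do not go with one direction across these compounds, although the two steps start from different groups and different compounds. No measurement here explains the rise seen with the 3,4-dihydroxyphenyl arm.

This single exchange removes the bromine and adds both hydroxyl groups at once, so the compounds shown leave open how much of the step belongs to each of those changes, and whether an arm with only one hydroxyl group would sit nearer to compound 3 or to compound 4. Also open, going by these compounds, is how this arm would read with an amine or a carboxylic acid in place of the hydroxyl groups.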